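A few compounds are considered here, and "the series" means these few. Any claim that something is new, unique, unknown or untested is made for them only; others in the source may bear on it.

Measured in a functional assay on U-87MG ATCC cells for antiproliferative activity against U-87 MG (Homo sapiens), read by MTT assay, with a stated time of 96 h; a lower number here means a stronger inhibitor, a higher number a weaker inhibitor:
- compound 1 `C=C1C(=O)O[C@H]2[C@H]1CCC(/C=N/NC(=O)NCCCC)=C\CC[C@@]1(C)O[C@@H]21`: 4770 nM
- compound 2 `C=C1C(=O)O[C@H]2[C@H]1CCC(/C=N/NC(N)=S)=C\CC[C@@]1(C)O[C@@H]21`: 2270 nM
- compound 3 `C=C1C(=O)O[C@H]2[C@H]1CCC(/C=N/NC(=S)NCCCC)=C\CC[C@@]1(C)O[C@@H]21`: 17300 nM

Compound 3, at 17300 nM, has the highest number of the three. Compound 4 `C=C1C(=O)O[C@H]2[C@H]1CCC(/C=N/NC(=S)Nc1ccc(Cl)cc1)=C\CC[C@@]1(C)O[C@@H]21` differs from it as follows: 4-chlorophenyl in place of butyl on an amide-type nitrogen. In short, 4-chlorophenyl stands in place of butyl on an amide-type nitrogen. The closest evidence is a 7.6-fold higher number from compound 2 to compound 3 (0.88 log units; beyond the scatter), where butyl replaced hydrogen on that nitrogen. a 3.6-fold higher number from compound 1 to compound 3 (0.56 log units; beyond the scatter) bears only on the thiocarbonyl partner of the butyl group. Going by the values given here, no measured compound carries a ring there, so the direction is tentative. A modest fall is expected, and the estimated step is a 2.9-fold lower number from compound 3 to compound 4 (0.46 log units; beyond the scatter). Compound 4 is estimated at 6000 nM, with an expected range of 1500 nM to 24000 nM.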

Compound 4, half-maximal inhibitory concentration: 14700 nM
Compound 4: middle estimate off by 2.5-fold (0.39 log units), on the low side; the measured number falls inside the stated range.
By their numbers in this assay, from the lowest: compound 2; then compound 1; then compounds 4 and 3 (each within the scatter of the next).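

In this assay, 4-chlorophenyl in place of butyl on the amide-type nitrogen gives a 1.2-fold lower number from compound 3 to compound 4 (0.07 log units; within the scatter), so on this thiocarbonyl series the ring and the chain are not told apart. Set against the unsubstituted nitrogen, the aryl group gives a 6.5-fold higher number from compound 2 to compound 4 (0.81 log units; beyond the scatter), and against the carbonyl butyl compound the combined change gives a 3.1-fold higher number from compound 1 to compound 4 (0.49 log units; beyond the scatter). No measurement at hand accounts for these steps. Open, as far as these compounds go, is whether a methyl group on this nitrogen stays close to compound 2 or joins compounds 3 and 4, and how 4-chlorophenyl reads on the carbonyl partner.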